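This account rests on a few compounds, and the source may have more. Where it says the series, first, only, none or still open, it means among the compounds named here.

For the measured compounds named here, in a functional assay on L1210 cells (Mus musculus) for inhibition, with a stated time of 96 h (on this read-out lower numbers stand for stronger inhibition and higher numbers for weaker inhibition), compound 2 (`CCCNCCCCNCCCCNCCC`) gives 6000 nM as the higher of the two numbers so far, and compound 1 (`CCCNCCCCNCCCCN`) gives 600 nM as the lower. Compound 3 (`CCCNCCCCCNCCCCNCCC`) differs from compound 2 in one place ((propylamino)methyl in place of propylamino on a saturated chain carbon, four bonds along the chain from an amine nitrogen). Going by the values given here, the only measured step, propyl in place of hydrogen on an amine nitrogen, is a different kind of change (a 10-fold higher number from compound 1 to compound 2 (1.00 log units; beyond the scatter)). It therefore points in no direction here, and no shift beyond the scatter is expected (a 1.2-fold lower number from compound 2 to compound 3 (0.08 log units; within the scatter)). For compound 3 the estimate is 5000 nM within an expected range of 1500 nM to 15000 nM on this read-out.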

Compound 3, half-maximal inhibitory concentration: 1200 nM
Compound 3: middle estimate off by 4.2-fold (0.62 log units), on the high side; measured number outside the range, below it.
By their numbers in this assay, from the lowest: compounds 1 and 3 (each within the scatter of the next); then compound 2.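

In this assay, (propylamino)methyl in place of propylamino on a saturated chain carbon, four bonds along the chain from an amine nitrogen, is no silent swap: it gives a 5.0-fold lower number from compound 2 to compound 3 (0.70 log units; beyond the scatter). Set against compound 1, the same place carrying (propylamino)methyl instead of amino gives a 2.0-fold higher number from compound 1 to compound 3 (0.30 log units; within the scatter), so this change brings the number back level with compound 1. Nothing available explains this shift. Still open, from the compounds shown here alone, is whether a longer chain at this place would lower the number further, and whether a carboxylic acid or an alcohol could replace the amine there.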